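A few compounds are considered here, and "the series" means these few. Any claim that something is new, unique, unknown or untested is made for them only; others in the source may bear on it.

In a functional assay on MCF7 cells (Homo sapiens) for antiproliferative activity (a higher number here means a weaker inhibitor, a lower number a stronger inhibitor), compound 1 `CC(C)=CCc1cc(C(=O)Nc2cc3ccc(OCCCN4CCCCC4)c(C)c3oc2=O)ccc1O` gives > 50000 nM and this is a limit of the assay, not a number. Compound 2 `CC(C)=CCc1cc(C(=O)Nc2cc3ccc(OCCCN(C)C(C)C)c(C)c3oc2=O)ccc1O` gives 1050 nM while compound 3 `CC(C)=CCc1cc(C(=O)Nc2cc3ccc(OCCCN(C(C)C)C(C)C)c(C)c3oc2=O)ccc1O` gives 1310 nM and the two stand level, with a 1.2-fold higher number from compound 2 to compound 3 (0.10 log units; within the scatter) inside the scatter. Both lie far from compound 1, as an at least 47-fold lower number from compound 1 to compound 2 (1.67 log units; beyond the scatter) and an at least 38-fold lower number from compound 1 to compound 3 (1.58 log units; beyond the scatter) are large steps. Compound 4 `CC(C)=CCc1cc(C(=O)Nc2cc3ccc(OCCCN(C)C(C)(C)C)c(C)c3oc2=O)ccc1O` differs from compound 3 by methyl(tert-butyl)amino in place of diisopropylamino on a saturated chain carbon, three bonds along the chain from an oxygen on an aromatic ring and, like diisopropylamino, methyl(tert-butyl)amino has no ring. Among the measured compounds shown here, the nearest precedent is the small step between compound 2 and compound 3, so no shift beyond the scatter is expected in this assay although the steps from compound 1 show that this amine can matter. The expected step is a 1.0-fold lower number from compound 3 to compound 4 (0.00 log units; within the scatter) and it stays modest. For compound 4 the estimated value is 1300 nM with an expected range from 500 nM to 5000 nM as its bounds.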

Compound 4, half-maximal inhibitory concentration: 1140 nM
Estimate against measurement, compound 4: 1.1-fold (0.06 log units) above; low and high end bracket the measured number.
By their numbers in this assay, from the lowest: compounds 2, 4 and 3 (each within the scatter of the next). At a limit, above all of these: compound 1.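

With a 1.1-fold lower number from compound 3 to compound 4 (0.06 log units; within the scatter) and a 1.1-fold higher number from compound 2 to compound 4 (0.04 log units; within the scatter) a third amine without a ring stands level with the other two at this place, so the added methyl on the chain carbon bound to the amine nitrogen shifts nothing beyond the scatter. The piperidin-1-yl of compound 1 remains the one outlier, with an at least 43-fold lower number from compound 1 to compound 4 (1.64 log units; beyond the scatter) as the gap. The entry for compound 1 is a limit, not a number: the limit of > 50000 nM in this assay, at which 1 of the 4 values shown sits.

Only one amine with a ring is shown, so it stays open whether any ring or only this one sets compound 1 apart. A pyrrolidin-1-yl or morpholin-4-yl group at the same place would test that, and a plain dimethylamino would show whether the open-chain amines stay level when smaller.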